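Removing a Methoxy Group from Compound 1

The source may hold more compounds than are shown below. What is called first, only, known or untested is meant among the compounds shown, and "the series" means these compounds.

Compound 1 `COc1ccc2sc(NC(=O)CCCCCCNC(=O)C(O)(O)C(F)(F)F)nc2c1`: 3650 nM
Compound 2 `O=C(CCCCCCNC(=O)C(O)(O)C(F)(F)F)Nc1ncc(-c2ccc(O)cc2)s1`: 1100 nM

In a functional assay on MDA-MB-468 cells (Homo sapiens) for inhibition, read by colorimetric assay, with a stated time of 3 days (on this read-out lower numbers stand for stronger inhibition and higher numbers for weaker inhibition), compound 1 stands at 3650 nM, the higher of the two numbers. Compound 2 comes in lower at 1100 nM, and this gap lies beyond the usual scatter, which makes compound 1 the weaker inhibitor of the pair.

Compound 3 `O=C(CCCCCCNC(=O)C(O)(O)C(F)(F)F)Nc1nc2ccccc2s1` differs from compound 1 in one place: hydrogen in place of methoxy on an aromatic carbon. In words, hydrogen takes the place of methoxy on an aromatic carbon, while the rest of the molecule stays the same. Going by the values given here, no measured pair shows what this swap does, and the two known values offer no direct guide. No step beyond the scatter is therefore expected in this assay. The estimated change is small: a 1.2-fold lower number from compound 1 to compound 3 (0.09 log units; within the scatter). The expected value for compound 3 is 3000 nM, with an estimated range from 1300 nM to 7000 nM.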

Compound 3, half-maximal inhibitory concentration: 1310 nM
For compound 3 the middle estimate is 2.3-fold (0.36 log units) above the measured one; low and high end bracket the measured number.
By their numbers in this assay, from the lowest: compounds 2 and 3 (each within the scatter of the next); then compound 1.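

In this assay, putting hydrogen in place of methoxy on the six-membered aromatic ring gives a 2.8-fold lower number from compound 1 to compound 3 (0.45 log units; beyond the scatter) and so shows that what sits at this position does affect the read-out. The step is modest, but it shows that the methoxy group is not needed for inhibition in these cells, as compound 3 inhibits more strongly without it. No measurement shown here accounts for this gain.

Going by these compounds, what a different group at this same position would do remains open: an amine, a fluorine atom or a longer ether such as ethoxy could give a number near that of compound 3, near that of compound 1, or outside both. Going by these compounds alone, this is also the only pair that shows this swap, so whether it gives a similar step on another core remains unknown.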